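Fluoro for acetyl: the step to compound 4

The source may report more compounds than this note shows. Statements on the series, on what has been measured and on what is new or still open speak of the compounds shown alone.

All numbers below come from a functional assay on HeLa cells (Homo sapiens) for inhibition, read by CCK-8 assay, with a stated time of 48 h; on this read-out lower numbers stand for stronger inhibition and higher numbers for weaker inhibition.
Compound 1, `COc1cc(-c2ccnc3c(-c4ccc(C)cc4)cnn23)cc(OC)c1OC`: compound 1 gives > 10000 nM, which is a limit of the assay and not a number.
Compound 2, `COc1cc(-c2ccnc3cc(-c4ccc(C(C)=O)cc4)nn23)cc(OC)c1OC`: compound 2 gives 1810 nM.
Compound 3, `COc1cc(-c2ccnc3cc(-c4ccc(-c5cnn(C)c5)cc4)nn23)cc(OC)c1OC`: compound 3 gives 1830 nM.

Compound 2 holds the lowest of the two numbers in this assay. Its nearest neighbour is compound 3, reached by a 1.0-fold higher number from compound 2 to compound 3 (0.00 log units; within the scatter), so the two cannot be told apart. Compound 1 sits at the limit, as the limit of > 10000 nM in this assay, at which 1 of the 3 values shown sits, shows.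

Compound 4, `COc1cc(-c2ccnc3cc(-c4ccc(F)cc4)nn23)cc(OC)c1OC`, has not yet been measured in this assay. It differs from compound 2 in one place: fluoro in place of acetyl on an aromatic carbon. Going by the values given here, the only measured step that touches this place is a 1.0-fold higher number from compound 2 to compound 3 (0.00 log units; within the scatter), where 1-methyl-1H-pyrazol-4-yl in place of acetyl on an aromatic carbon left the number where it was. That step exchanged the acetyl for a larger group, whereas fluoro is a single heavy atom, so its bearing is indirect. Among the compounds with values here, with one neutral step as the only guide, no change beyond the scatter is expected in this assay, though the range must stay wide. Compound 4 is therefore expected to give 3000 nM, between 1000 nM and 10000 nM. The step this estimate implies is a 1.7-fold higher number from compound 2 to compound 4 (0.22 log units; within the scatter), and it is an expectation only.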

Compound 4, half-maximal inhibitory concentration: 5840 nM
Compound 4: middle estimate off by 1.9-fold (0.29 log units), on the low side, and the stated range covers the measured number.
By their numbers in this assay, from the lowest: compounds 2 and 3 (each within the scatter of the next); then compound 4. At a limit, above all of these: compound 1.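

Going by these compounds alone, the exchange of acetyl for fluoro is the first change at this position that moves the number beyond the scatter in this assay (a 3.2-fold higher number from compound 2 to compound 4 (0.51 log units; beyond the scatter)), whereas the exchange of acetyl for 1-methyl-1H-pyrazol-4-yl left it within the scatter (a 1.0-fold higher number from compound 2 to compound 3 (0.00 log units; within the scatter)); the position is therefore not indifferent to the group it carries. The step from the pyrazole-bearing compound is of similar size (a 3.2-fold higher number from compound 3 to compound 4 (0.50 log units; beyond the scatter)), so among these three compounds, two quite different larger groups cannot be told apart, while fluoro, the smaller group, gives the higher number and the weaker inhibition. Nothing shown here measures a property that would account for this step.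

Three groups at this place cannot show whether the number follows the size of the group or some other feature of it. Going by these compounds, how an amine, a carboxylic acid or a nitrile on this aromatic carbon would compare in this assay remains open, as does whether any group here can bring the number clearly lower than those of compound 2 and compound 3.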